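The source may hold more compounds than are shown below. What is called first, only, known or untested is meant among the compounds shown, and "the series" means these compounds.

Measured compounds in an ADME assay on C8166 cells (Homo sapiens) for cytotoxicity, read by MTT assay; a lower number here means that less compound is tolerated, a higher number that more compound is tolerated:

compound 1, `Cc1cc(S(N)(=O)=O)ccc1NC(=O)COc1ccc(Cl)cc1C(O)c1ccccc1`, 33400 nM
compound 2, `Cc1cccc(C(O)c2cc(Cl)ccc2OCC(=O)Nc2ccc(S(N)(=O)=O)cc2C)c1`, 33200 nM
compound 3, `Cc1cc(S(N)(=O)=O)ccc1NC(=O)COc1ccc(Cl)cc1C(O)c1cccc(Cl)c1`, 33300 nM

Compound 2 sits among three numbers that cannot be told apart in this assay: the step of a 1.0-fold lower number from compound 1 to compound 2 (0.00 log units; within the scatter) and the step of a 1.0-fold higher number from compound 2 to compound 3 (0.00 log units; within the scatter) both fall inside the scatter, as does a 1.0-fold lower number from compound 1 to compound 3 (0.00 log units; within the scatter). Across these three compounds, swapping substituents on the phenyl ring that hangs from the hydroxy-bearing carbon has left the cytotoxicity reading where it was.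

Compound 4, `Cc1ccc(C(O)c2cc(Cl)ccc2OCC(=O)Nc2ccc(S(N)(=O)=O)cc2C)c(C)c1`, has not yet been measured in this assay. It differs from compound 2 in one place: 2,4-dimethylphenyl in place of 3-methylphenyl on a saturated chain carbon bound to an aromatic carbon and an oxygen on a saturated carbon. Compound 2 to compound 4 therefore adds a second methyl to that same ring, a change of the same kind as the substitutions already covered by the steps from compound 1 to compound 2 and from compound 1 to compound 3, neither of which moved the number beyond the scatter.

On that basis no step beyond the scatter is expected from compound 2 to compound 4 in this assay, and a 1.0-fold lower number from compound 2 to compound 4 (0.00 log units; within the scatter) is the estimated change. For compound 4 the expected reading is 33000 nM, with a range from 16000 nM to 66000 nM.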

Compound 4, half-maximal cytotoxic concentration: 26400 nM
Estimate against measurement, compound 4: 1.3-fold (0.10 log units) above; the measured number falls inside the stated range.
By their numbers in this assay, from the lowest: compounds 4, 2, 3 and 1 (each within the scatter of the next).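

In this assay, the place on the saturated chain carbon bound to an aromatic carbon and an oxygen on a saturated carbon now also carries 2,4-dimethylphenyl, and this group cannot be told apart from any of the three earlier rings: in place of 3-methylphenyl it gives (a 1.3-fold lower number from compound 2 to compound 4 (0.10 log units; within the scatter)), in place of 3-chlorophenyl (a 1.3-fold lower number from compound 3 to compound 4 (0.10 log units; within the scatter)), and in place of phenyl (a 1.3-fold lower number from compound 1 to compound 4 (0.10 log units; within the scatter)). The earlier compounds shown here showed only an unsubstituted phenyl and rings with a single substituent, so compound 4 extends the flat reading to a ring with a second methyl, and all four compounds remain within the scatter of one another. No measurement at hand speaks to why the reading holds across these rings.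

From the compounds shown here alone, whether an amine or a carboxylic acid on this ring, or a longer chain in place of a methyl, would move the number beyond the scatter stays open. Also open, going by these compounds, is how a change elsewhere would read, as all four compounds share the rest of the core of compound 1 unchanged.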